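This account rests on a few compounds, and the source may have more. Where it says the series, first, only, none or still open, it means among the compounds named here.

In a physicochemical assay for solubility, measured as kinetic solubility, with a stated time of 1 h, at pH 7.4 (on this read-out lower numbers stand for lower solubility and higher numbers for higher solubility), compound 1 (`CC(=O)NC1=NN(c2ccc(Cl)c(Cl)c2)CC1`) gives 31000 nM as its reading, compound 2 (`O=C1CCCC(C(=O)NC2=NN(c3ccc(Cl)c(Cl)c3)CC2)N1`) gives 416000 nM and compound 3 (`O=C(NC1=NN(c2ccc(Cl)c(Cl)c2)CC1)c1cccnc1`) gives 4000 nM as the lowest of the three numbers, with compound 1 its nearest neighbour.

Compound 4 (`O=C(NC1=NN(c2ccc(Cl)c(Cl)c2)CC1)c1ccncc1`) carries pyridin-4-yl in place of pyridin-3-yl on a carbonyl carbon, with the same atoms joined differently.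

The measured steps at this carbonyl carbon were large in a 13-fold higher number from compound 1 to compound 2 (1.13 log units; beyond the scatter) and in a 100-fold lower number from compound 2 to compound 3 (2.02 log units; beyond the scatter) and modest in a 7.8-fold lower number from compound 1 to compound 3 (0.89 log units; beyond the scatter) but each of them exchanges unlike groups. Going by the values given here, no measurement yet compares two pyridinyl groups, so those sizes set no direction here. A step within the scatter is expected, with neither direction clearly favoured. The expected change is a 1.3-fold higher number from compound 3 to compound 4 (0.10 log units; within the scatter) and nothing larger is anticipated. Compound 4 is estimated at 5000 nM with an expected range from 1800 nM to 15000 nM as the working figure.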

Compound 4, solubility: 9000 nM
The estimate for compound 4 lay 1.8-fold (0.26 log units) below the measured number, and the stated range covers the measured number.
By their numbers in this assay, from the lowest: compound 3; then compound 4; then compound 1; then compound 2.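

In this assay, going by these compounds alone, the first comparison of two pyridinyl groups on this carbonyl carbon gives a 2.3-fold higher number from compound 3 to compound 4 (0.35 log units; beyond the scatter) and shows that with the same atoms joined differently, the reading can still move beyond the scatter. The change does not lift pyridin-4-yl past the other groups: the series shows a 3.4-fold lower number from compound 1 to compound 4 (0.54 log units; beyond the scatter) and a 46-fold lower number from compound 2 to compound 4 (1.66 log units; beyond the scatter) so both pyridinyl compounds remain under compound 1 and compound 2 in this read-out. Nothing available accounts for the step between the two pyridinyl groups.

The compounds shown leave open how pyridin-2-yl, a plain phenyl ring or a pyridine ring carrying an amine would read on this carbonyl carbon. Also open, going by these compounds, is whether the step between pyridin-3-yl and pyridin-4-yl keeps its direction on a different core.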